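The compounds below may be only part of what the source reports. "The series", "measured", "known", "first", "only" and "open" are said of these compounds alone.

Measured in an ADME assay on PC-3 cells (Homo sapiens) for cytotoxicity, read by WST assay, tested at 100 uM; a higher number here means more inhibition at the concentration tested (going by the name of the read-out), a lower number less inhibition:
compound 1 `O=C(Nc1cccc(N2CCCC2=O)c1)C1CCCN(C(=O)c2cc(C(F)(F)F)cc(C(F)(F)F)c2)C1` — 0%
compound 2 `O=C(Nc1cccc([N+](=O)[O-])c1)C1CCCN(C(=O)c2cc(C(F)(F)F)cc(C(F)(F)F)c2)C1` — 9%
compound 3 `O=C(Nc1cccc(CN2CCCC2)c1)C1CCCN(C(=O)c2cc(C(F)(F)F)cc(C(F)(F)F)c2)C1` — 51%

Compound 3 gives the highest of the three numbers in this assay; the nearest is compound 2 and the furthest compound 1, both separated from it beyond the scatter. The two steps leading to compound 3 are large: a number 51 percentage points higher from compound 1 to compound 3 (beyond the scatter) and a number 42 percentage points higher from compound 2 to compound 3 (beyond the scatter), while a number 9 percentage points higher from compound 1 to compound 2 (within the scatter) stays within the scatter. The next compound is compound 4 `O=C(Nc1cccc(OCCc2ccccn2)c1)C1CCCN(C(=O)c2cc(C(F)(F)F)cc(C(F)(F)F)c2)C1`.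

2-(pyridin-2-yl)ethoxy in place of (pyrrolidin-1-yl)methyl on an aromatic carbon

Going by the values given here, no measured step exchanges (pyrrolidin-1-yl)methyl for 2-(pyridin-2-yl)ethoxy, so the measured steps bear on it only indirectly: at this position the two other groups gave small numbers, compound 1 with 0% and compound 2 with 9%, and the number rises only with (pyrrolidin-1-yl)methyl in compound 3. The expectation is therefore a drop from compound 3, estimated as a number 31 percentage points lower from compound 3 to compound 4 (beyond the scatter), with wide uncertainty. Compound 4 is estimated at 20%, with a range from 0% to 50%.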

Compound 4, a percentage reported as inhibition, at one concentration (the size of the read-out at that concentration, not a potency): 5%
For compound 4 the middle estimate is 15 percentage points above the measured one; measured number inside the range.
By their numbers in this assay, from the lowest: compounds 1, 4 and 2 (each within the scatter of the next); then compound 3.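

In this assay, 2-(pyridin-2-yl)ethoxy in place of (pyrrolidin-1-yl)methyl gives a number 46 percentage points lower from compound 3 to compound 4 (beyond the scatter) on the same aromatic carbon, so the high number does not carry over to this larger group with its nitrogen-bearing ring. Going by these compounds alone, the steps of a number 4 percentage points lower from compound 2 to compound 4 (within the scatter) and a number 5 percentage points higher from compound 1 to compound 4 (within the scatter) place 2-(pyridin-2-yl)ethoxy with nitro and 2-oxopyrrolidin-1-yl, which leaves (pyrrolidin-1-yl)methyl as the only group of the four that stands apart at this position. Nothing available here accounts for that difference.

Still open, from the compounds shown here alone, is which part of (pyrrolidin-1-yl)methyl goes with the high number. A piperidin-1-ylmethyl group, a dimethylaminomethyl group, a pyrrolidin-1-yl ring placed directly on the aromatic carbon or a 2-(pyrrolidin-1-yl)ethoxy chain would each separate the ring, the amine and the link.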